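The compounds below may be only part of what the source reports. "The series", "measured", "known", "first", "only" and "open" are said of these compounds alone.

Measured compounds:
Compound 1 `COc1cc(NCc2ccc(Cl)cc2)cc(OC)c1OC` — > 80000 nM
Compound 2 `COc1ccc(CNc2cc(OC)c(OC)c(OC)c2)cc1Br` — 48100 nM
Compound 3 `C/C=C/C=C/C(=O)N(Cc1ccc(OC)c(O)c1)c1cc(OC)c(OC)c(OC)c1` — 180 nM

In a functional assay on HCT-116 cells (Homo sapiens) for inhibition, read by MTT assay, with a stated time of 48 h (on this read-out lower numbers stand for stronger inhibition and higher numbers for weaker inhibition), compound 1 gives > 80000 nM, which is a limit of the assay and not a number. Compound 2 gives 48100 nM in this assay. Compound 3, with 180 nM, has the lowest of the two numbers, and its gap to compound 2 lies far beyond the scatter.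

Compound 4 `COc1ccc(CN(C(=O)/C=C/CBr)c2cc(OC)c(OC)c(OC)c2)cc1O` is not yet measured. It differs from compound 3 in one place: bromomethyl in place of prop-1-en-1-yl on a double-bonded chain carbon bound to a double-bonded chain carbon. Going by the values given here, no measured pair isolates this change, so the expectation rests on compound 3 alone. The step from compound 3 to compound 4 is estimated at a 1.9-fold higher number from compound 3 to compound 4 (0.29 log units; within the scatter), a small move toward a higher number that may well stay within the scatter. Compound 4 is expected to give about 350 nM in this assay, between 70 nM and 1800 nM.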

Compound 4, half-maximal inhibitory concentration: 59 nM
Compound 4: middle estimate off by 5.9-fold (0.77 log units), on the high side, outside the stated range (below it).
By their numbers in this assay, from the lowest: compound 4; then compound 3; then compound 2. At a limit, above all of these: compound 1.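

Within this assay, bromomethyl in place of prop-1-en-1-yl on a double-bonded chain carbon bound to a double-bonded chain carbon gives a 3.1-fold lower number from compound 3 to compound 4 (0.48 log units; beyond the scatter). This position therefore accepts the change from penta-1,3-dien-1-yl to 3-bromoprop-1-en-1-yl, and in this pair the second chain double bond is not needed to keep the number low. Nothing shown here gives a reason for this step. From the compounds shown here alone, what a chloromethyl, methyl or aminomethyl group would give at this place remains open. The bromine's contribution therefore cannot be separated from that of the chain change.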